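Acetyl to Vinylcarbonyl on a Trimethoxyphenyl Amide

The compounds below may be only part of what the source reports. "The series", "measured", "known", "first", "only" and "open" are said of these compounds alone.

Measured so far:
compound 1 `COc1ccc(CN(C(C)=O)c2cc(OC)c(OC)c(OC)c2)cc1O` — 270 nM
compound 2 `COc1ccc(CNc2cc(OC)c(OC)c(OC)c2)cc1Cl` — 41700 nM
compound 3 `C/C=C/C(=O)N(Cc1cc(OC)c(OC)c(OC)c1)c1ccc(OC)c(O)c1` — 8450 nM

Of the compounds shown here, three have been tested in a functional assay on HCT-116 cells (Homo sapiens) for inhibition, read by MTT assay, with a stated time of 48 h; on this read-out lower numbers stand for stronger inhibition and higher numbers for weaker inhibition. Compound 1 gives 270 nM, the lowest of the three numbers. Its nearest neighbour is compound 3, whose value of 8450 nM lies beyond the scatter above it, and compound 2, with 41700 nM, lies further still. Within the data shown here, none of these pairs differs in only one place, so no single step can be read from them; the values show only that compound 1 is the most potent of the three.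

Compound 4 `C=CC(=O)N(Cc1ccc(OC)c(O)c1)c1cc(OC)c(OC)c(OC)c1` is not yet measured. It differs from compound 1 by vinyl in place of methyl on a carbonyl carbon, the change reading acetyl to vinylcarbonyl when cut one bond further out, on a carbonyl carbon whose other neighbour is an amide-type nitrogen. Among the measured compounds shown here, no measured pair shows this change, so the direction is open. For compound 4 the writer expects a step of a 1.5-fold higher number from compound 1 to compound 4 (0.17 log units; within the scatter), within the scatter. Compound 4 is estimated at 400 nM, in the range 120 nM to 1500 nM.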

Compound 4, half-maximal inhibitory concentration: 98 nM
Compound 4: middle estimate off by 4.1-fold (0.61 log units), on the high side; the whole stated range lies above it.
By their numbers in this assay, from the lowest: compound 4; then compound 1; then compound 3; then compound 2.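

Among these compounds, the step from acetyl to vinylcarbonyl gives the first single-change reading at this position: in this assay, vinyl in place of methyl on a carbonyl carbon whose other neighbour is an amide-type nitrogen gives a 2.8-fold lower number from compound 1 to compound 4 (0.44 log units; beyond the scatter), a modest step. It shows that the methyl of compound 1 is not required for activity and that this carbonyl carbon accepts a change that lowers the number. Nothing at hand measures why vinyl gives the lower number.

The compounds shown leave open whether the double bond itself matters, since an ethyl group on the same carbonyl carbon would separate it from the added carbon. Also open, from the compounds shown here alone, is how a longer chain or a chain carrying an amine would read at this position.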